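The compounds below may be only part of what the source reports. "The series", "measured", "known", "first", "only" and "open" are said of these compounds alone.

Measured in a functional assay on A549 cells (Homo sapiens) for antiproliferative activity, read by sulforhodamine B assay, with a stated time of 72 h; a higher number here means a weaker inhibitor, a lower number a stronger inhibitor:
- compound 1 `COc1cc2occ(-c3csc4ccccc34)c(=O)c2c(OC)c1O`: > 10000 nM
- compound 2 `O=C(/C=C/c1cc2ccccc2s1)c1cc(Cl)ccc1O`: > 10000 nM
- compound 3 `O=C(/C=C/c1cc2ccccc2s1)c1cc(Br)ccc1O`: > 10000 nM

Compound 3 stands at > 10000 nM, which is a limit and not a number. The whole set reads the same way: the limit of > 10000 nM in this assay, at which 3 of the 3 values shown sit.

Compound 4 `COc1ccc(O)c(C(=O)/C=C/c2cc3ccccc3s2)c1` follows from compound 3 by methoxy in place of bromo on an aromatic carbon, para to a hydroxy group. Among the measured compounds shown here, the only measured step that bears on this is a step that the two limits leave unreadable from compound 2 to compound 3, so it offers no size to carry over. The expected step in this assay is a step that the limit leaves unreadable from compound 3 to compound 4, and no direction can be claimed for it. Compound 4 is expected to remain weak, close to the limit of the assay. The estimate for compound 4 is 12000 nM, with an expected range of 4000 nM to 30000 nM.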

Compound 4, half-maximal inhibitory concentration: > 10000 nM
Compound 4: a limit, no number; the forecaster's own chance of this, stated with the estimate: 80%; the middle value does not contradict the limit.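

In this assay compound 4 gives > 10000 nM, a limit and not a number. Among the compounds shown here, no step from compound 2 or compound 3 to compound 4 can be read. The compounds shown leave open whether chloro, bromo and methoxy on this aromatic carbon differ at all in antiproliferative activity.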